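A Bromobenzyl Swap at the Amine of Compound 2

This account rests on a few compounds, and the source may have more. Where it says the series, first, only, none or still open, it means among the compounds named here.

Compound 2, `COc1cc(Oc2cccc(Nc3ccccc3)c2)cc(OC)c1CN[C@H](C)c1ccccc1`, is the starting point. In a functional assay on HCT-15 cells (Homo sapiens) for inhibition, read by MTT assay, with a stated time of 72 h (on this read-out lower numbers stand for stronger inhibition and higher numbers for weaker inhibition), compound 2 gives 7550 nM, the higher of the two numbers recorded so far. Among the measured compounds shown here, its only companion is compound 1, `COc1ccc(CCCNCc2c(OC)cc(Oc3ccc(Nc4ccccc4)cc3)cc2OC)cc1`, which in this assay gives 2180 nM; the two structures differ in more than one place, so their gap tells only that compound 1 inhibits more strongly, and says nothing about any single group.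

Compound 3, `COc1cc(Oc2cccc(Nc3ccccc3)c2)cc(OC)c1CNCc1ccc(Br)cc1`, differs from compound 2 in one place: 4-bromobenzyl in place of 1-phenylethyl on an amine nitrogen. For the measured compounds named here, no measured pair of compounds differs in a single place, so there is no measured step against which this change can be weighed. With nothing in the data to point either way, the step from compound 2 to compound 3 in this assay is expected to stay within the scatter of repeated measurements, or at most to be a small one toward stronger inhibition, a 1.5-fold lower number from compound 2 to compound 3 (0.18 log units; within the scatter). On that basis compound 3 is estimated to give 5000 nM in this assay, with a plausible range from 1500 nM to 15000 nM.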

Compound 3, half-maximal inhibitory concentration: 5410 nM
Compound 3: the middle estimate sits 1.1-fold (0.03 log units) below what was measured, within the range that was stated.
By their numbers in this assay, from the lowest: compound 1; then compounds 3 and 2 (each within the scatter of the next).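

Among the compounds shown here, this is the first step that can be read at a single place: in this assay, 4-bromobenzyl in place of 1-phenylethyl on the amine nitrogen gives a 1.4-fold lower number from compound 2 to compound 3 (0.14 log units; within the scatter) and so leaves the number within the scatter. This exchange keeps the heavy-atom count and the six-membered aromatic ring of carbon only, while a bromine enters and the defined stereocentre leaves, so this one pair shows that the two differences taken together do not move the read-out beyond the scatter, though it cannot show what either does alone. Nothing measured on these groups accompanies the result, so no explanation for it can be offered from the data.

A plain benzyl group on the same nitrogen would be needed to separate the bromine from the loss of the stereocentre, and the mirror-image form of the 1-phenylethyl group would bear on the stereocentre itself. From the compounds shown here alone, whether a 4-chlorobenzyl or a 3-bromobenzyl group would read the same way also stays open, as does the effect of a longer chain at this nitrogen on the core of compound 2.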